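The compounds below may be only part of what the source reports. "The series", "measured", "known", "first", "only" and "open" are said of these compounds alone.

Of the compounds shown here, three of one series have so far been tested in a functional assay on the whole organism with Rattus norvegicus as the target; on this read-out lower numbers stand for an effect already at smaller amounts and higher numbers for an effect only at larger amounts of compound. Compound 1 `Nc1nc2ccc(SC(F)(F)F)cc2s1` gives 8 mg/kg in this assay. Compound 2 `Nc1nc2ccc(OCC(F)(F)C(F)(F)F)cc2s1` gives 7.5 mg/kg. Compound 3 `C#CCn1c(=N)sc2cc(OC(F)(F)F)ccc21` gives 4 mg/kg, the lowest of the three numbers, though its gaps to compound 2 and to compound 1 both lie within the usual scatter of such measurements, so no order among the three can be read from them. All three values sit in a narrow band.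

Compound 4 `C[S+]([O-])Cn1c(=N)sc2cc(OC(F)(F)F)ccc21` has not yet been measured. Compared with compound 3, it differs in a single place: a group of 3 heavy atoms (1 carbon, 1 oxygen, 1 sulfur; no ring) in place of a group of 2 heavy atoms (2 carbon; no ring), on a saturated chain carbon bound to an aromatic nitrogen. Within the data shown here, no pair of measured compounds shows a change of this kind, so there is no step from which to read its effect directly. What the measured set does show is that rather different substituents on this core have left the read-out in this assay nearly unchanged, and a change confined to the group on the saturated chain carbon is expected to behave much the same. The step from compound 3 to compound 4 in this assay is therefore expected to be small, a 1.3-fold higher number from compound 3 to compound 4 (0.10 log units; within the scatter), with no direction beyond the scatter. For compound 4 the estimated value in this assay is 5 mg/kg, within a range from 2 mg/kg to 12 mg/kg.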

Compound 4, dose for half-maximal effect: 2.3 mg/kg
For compound 4 the middle estimate is 2.2-fold (0.34 log units) above the measured one; measured number inside the range.
By their numbers in this assay, from the lowest: compounds 4, 3, 2 and 1 (each within the scatter of the next, the first and the last beyond it).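

In this assay, the ethynyl group gives way to a group of 3 heavy atoms on a saturated chain carbon bound to an aromatic nitrogen, and this yields a 1.7-fold lower number from compound 3 to compound 4 (0.24 log units; within the scatter). Among these compounds, this is the first step that can be read at this place, and it stays within the scatter. At this place, then, the read-out does not separate the two groups, even though a triple bond leaves and a hydrogen-bond acceptor enters, so neither feature shows any effect beyond the scatter in this single comparison. Nothing available here bears on the reason for this result.

Going by these compounds, a single step cannot show whether this place tolerates change in general, so it remains open whether an amine, a carboxylic acid or a longer chain on the same saturated chain carbon would also stay within the scatter of compound 3. Among the compounds shown here, it also remains open whether the same exchange would give a similarly small step on a core carrying a different group elsewhere, since only this one pair shows the change.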